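Exposure after Swapping the Thiazole for an Imidazole

This account rests on a few compounds, and the source may have more. Where it says the series, first, only, none or still open, it means among the compounds named here.

In an ADME assay on the whole organism (plasma, strain 129/SvEvBrd x C57BL/6) for pharmacokinetics, with Mus musculus as the target, at a dose of 10 mg/kg by the oral route (on this read-out higher numbers stand for higher exposure at the dose given and lower numbers for lower exposure), compound 2 (`Cc1nc(-c2nc([C@@H](O)[C@H](O)[C@H](O)CO)c[nH]2)cs1`) gives 1970 ng.h/mL. That value lies within the usual scatter of compound 1 (`CC(=O)c1nc([C@@H](O)[C@H](O)[C@H](O)CO)c(-c2ccccc2)[nH]1`), at 3520 ng.h/mL. Compound 3 (`OC[C@@H](O)[C@@H](O)[C@H](O)c1c[nH]c(-c2ncn(Cc3ccccc3)n2)n1`), at 587 ng.h/mL, lies lower than compound 2, and that gap goes beyond the scatter.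

Compound 4 (`OC[C@@H](O)[C@@H](O)[C@H](O)c1c[nH]c(-c2ncc[nH]2)n1`) differs from compound 2 at one place, on an aromatic carbon between two ring nitrogen atoms, where 1H-imidazol-2-yl stands in place of 2-methyl-1,3-thiazol-4-yl: 1H-imidazol-2-yl in place of 2-methyl-1,3-thiazol-4-yl on an aromatic carbon. Within the data shown here, no measured pair isolates this change, so any expectation is loose. Among the measured compounds shown here, compound 3 also carries a different group at this place, and its value of 587 ng.h/mL marks the only lower reading available. The expectation therefore leans downward, with compound 4 likely to fall somewhere in the span of compound 3 and compound 2.

The expected change is a 1.6-fold lower number from compound 2 to compound 4 (0.22 log units; within the scatter), a modest fall that may not clear the scatter. In this assay compound 4 is estimated at 1200 ng.h/mL, within an expected range of 350 ng.h/mL to 4000 ng.h/mL.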

Compound 4, area under the concentration-time curve: 1500 ng.h/mL
Compound 4: the middle estimate sits 1.3-fold (0.10 log units) below what was measured; the measured number falls inside the stated range.
By their numbers in this assay, from the lowest: compound 3; then compounds 4, 2 and 1 (each within the scatter of the next, the first and the last beyond it).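

In this assay, among these compounds, the change to 1H-imidazol-2-yl in place of 2-methyl-1,3-thiazol-4-yl gives a 1.3-fold lower number from compound 2 to compound 4 (0.12 log units; within the scatter) and provides the first direct reading of a single change on this aromatic carbon between two ring nitrogen atoms. The two compounds cannot be told apart here, even though the entering ring has 1 hydrogen-bond donor and no sulfur, while the leaving ring has 0 hydrogen-bond donors and carries sulfur. Nothing at hand explains this outcome.

The compounds shown leave open how this place would read with a group that is not an aromatic ring, such as an amine or a carboxylic acid. They also leave open whether a methyl group on the 1H-imidazol-2-yl ring would give a reading distinct from that of compound 4.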